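Trimming the Ketone Side Chain Down to Acetyl

The compounds below may be only part of what the source reports. "The series", "measured", "known", "first", "only" and "open" are said of these compounds alone.

Three compounds sharing one core have been measured in an assay on HEK293 cells for positive allosteric modulation of metabotropic glutamate receptor 3 (Rattus norvegicus), read by thallium flux, with a stated time of 2.5 min; on this read-out lower numbers stand for smaller maximal responses and higher numbers for larger maximal responses:

compound 1, `CCC(=O)c1ccc(OCCCCOc2cc(C(=O)O)ccc2OC)c(C)c1O`, gives 62.5%;
compound 2, `CCCC(=O)c1ccc(OCCCCOc2cc(C(=O)O)ccc2OC)c(C)c1O`, gives 64.2%;
compound 3, `COc1ccc(C(=O)O)cc1OCCCCOc1ccc(C(=O)CC2CCCC2)c(O)c1C`, gives 67.6%.

Compound 3 holds the highest of the three numbers, but its neighbours sit close: a number 3.4 percentage points higher from compound 2 to compound 3 (within the scatter) and a number 5.1 percentage points higher from compound 1 to compound 3 (within the scatter), so no ordering can be read from them. Compound 4, `COc1ccc(C(=O)O)cc1OCCCCOc1ccc(C(C)=O)c(O)c1C`, remains to be measured. The change from compound 3 is hydrogen in place of cyclopentyl on a saturated chain carbon bound to a carbonyl carbon. Going by the values given here, three steps bear on this part of the molecule, all at the saturated chain carbon bound to the carbonyl carbon or one bond further along: a number 1.7 percentage points higher from compound 1 to compound 2 (within the scatter), a number 5.1 percentage points higher from compound 1 to compound 3 (within the scatter) and a number 3.4 percentage points higher from compound 2 to compound 3 (within the scatter). Every change at this position has stayed within the scatter, with the smaller groups tending to give slightly lower numbers. Removing the cyclopentyl entirely goes one step further than any measured compound, so the expectation is a step of a number 7.6 percentage points lower from compound 3 to compound 4 (within the scatter), without leaving the scatter. Compound 4 is therefore estimated at 60%, within a range from 48% to 72%.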

Compound 4, largest response reached (reported as percent of maximum), in percent of the reference or control that the assay uses: 34.8%
For compound 4 the middle estimate is 25.2 percentage points above the measured one; measured number below the stated range.
By their numbers in this assay, from the lowest: compound 4; then compounds 1, 2 and 3 (each within the scatter of the next).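

Going by these compounds alone, replacing the group on the saturated chain carbon bound to a carbonyl carbon with hydrogen is the first change here to leave the scatter in this assay, and it does so from all three earlier compounds: a number 32.8 percentage points lower from compound 3 to compound 4 (beyond the scatter), a number 29.4 percentage points lower from compound 2 to compound 4 (beyond the scatter) and a number 27.7 percentage points lower from compound 1 to compound 4 (beyond the scatter). Methyl at this carbon already holds the number as well as ethyl or cyclopentyl do within the scatter, so among these compounds the sharp divide lies between hydrogen and any of the three carbon groups, not in the size of the group. No measurement shown here accounts for this drop.

Going by these compounds, whether a fluorine atom, a hydroxyl group or an amine on this carbon would also keep the higher numbers stays open. So does whether a side chain that keeps the acetyl but changes the butoxy linker or the carboxylic acid would recover them.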